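The compounds below may be only part of what the source reports. "The series", "measured", "known", "first", "only" and "open" are said of these compounds alone.

Compound 2 `Oc1cccc(-c2nc(N3CCCCC3)c3nc[nH]c3n2)c1` is the starting point. In an assay on cells for displacement of a labelled ligand from adenosine receptor A2b (Homo sapiens), read by scintillation counting and radioligand binding, with a stated time of 30 min, tested at 10 uM (on this read-out higher numbers stand for more inhibition at the one concentration tested (going by the name of the read-out) and lower numbers for less inhibition), compound 2 gives > 80%, which is a limit of the assay rather than a number, namely (the limit of > 80% in this assay, at which 1 of the 3 values shown sits). Compound 1 `Clc1ccc(-c2nc(N3CCCCC3)c3nc[nH]c3n2)cc1` differs from it by 4-chlorophenyl in place of 3-hydroxyphenyl on an aromatic carbon and in this assay compound 1 gives 1.4%, a step of a number at least 78.6 percentage points lower from compound 2 to compound 1 (beyond the scatter). Compound 3 `CN1CCN(c2nc(-c3cccc(O)c3)nc3[nH]cnc23)CC1` carries a different core, (4-methylpiperazin-1-yl in place of piperidin-1-yl on an aromatic carbon), and in this assay compound 3 gives 27%, a step of a number at least 53 percentage points lower from compound 2 to compound 3 (beyond the scatter). Compound 4 `CN1CCN(c2nc(-c3ccc(Cl)cc3)nc3[nH]cnc23)CC1` has not yet been measured; it stands to compound 3 as compound 1 stands to compound 2, (4-chlorophenyl in place of 3-hydroxyphenyl on an aromatic carbon). This is the same kind of change, though the surroundings differ: the new group is meta to a 4-methylpiperazin-1-yl group rather than meta to a piperidin-1-yl group. The step is expected to be a number 23 percentage points lower from compound 3 to compound 4 (beyond the scatter), resting on the measured step of a number at least 78.6 percentage points lower from compound 2 to compound 1 (beyond the scatter). Compound 4 is therefore expected to give about 4%, within 0% to 15%.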

Compound 4, a percentage reported as inhibition, at one concentration (the size of the read-out at that concentration, not a potency): 6.2%
Beside the measured number, compound 4's estimate is 2.2 percentage points below it, within the range that was stated.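

In this assay, 4-chlorophenyl in place of 3-hydroxyphenyl again gives a lower number on the second core, a number 20.8 percentage points lower from compound 3 to compound 4 (beyond the scatter), so the direction of the change carries over but its size does not: the same change on two cores in this assay, a number at least 78.6 percentage points lower (beyond the scatter) from compound 2 to compound 1 and a number 20.8 percentage points lower (beyond the scatter) from compound 3 to compound 4, at least 57.8 percentage points apart, beyond the scatter of two such steps. Likewise, 4-methylpiperazin-1-yl in place of piperidin-1-yl gives no step beyond the scatter when 4-chlorophenyl is present, a number 4.8 percentage points higher from compound 1 to compound 4 (within the scatter), so that change also depends on its surroundings: the same change on two cores in this assay, a number at least 53 percentage points lower (beyond the scatter) from compound 2 to compound 3 and a number 4.8 percentage points higher (within the scatter) from compound 1 to compound 4, at least 57.8 percentage points apart, beyond the scatter of two such steps. Compound 2 gives > 80%, which is a limit of the assay and not a number, and these compounds do not show why the steps differ.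

Still open, as far as these compounds go, is how a phenyl ring carrying a methoxy group or an amine would behave on either core. A morpholine ring in place of the piperidin-1-yl group is also left open.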